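Replacing the cyclopentyl group of compound 2 with ethoxymethyl

The source may report more compounds than this note shows. Statements on the series, on what has been measured and on what is new or still open speak of the compounds shown alone.

Compound 1 (`COc1cccc(OC)c1-c1c(C2CC2)[nH]c(=O)c(-c2nnc(Cc3ccc(Cl)cc3)o2)c1O`) in a physicochemical assay for solubility, in phosphate buffer, with a stated time of 24 h, at pH 7.4 (a higher number here means a more soluble compound, a lower number a less soluble compound), gives 12 ug/mL
Compound 2 (`COc1cccc(OC)c1-c1c(C2CCCC2)[nH]c(=O)c(-c2nnc(Cc3ccc(Cl)cc3)o2)c1O`) in this assay gives 4 ug/mL

Compound 2 holds the lower of the two numbers (4 ug/mL), and compound 1 stands above it by a margin beyond the scatter. Compound 3 (`CCOCc1[nH]c(=O)c(-c2nnc(Cc3ccc(Cl)cc3)o2)c(O)c1-c1c(OC)cccc1OC`) shares the core of compound 2 but has ethoxymethyl in place of cyclopentyl on an aromatic carbon. For the measured compounds named here, one measured step bears on this change, since it also involves cyclopentyl on an aromatic carbon: the modest move (a 3.0-fold lower number from compound 1 to compound 2 (0.48 log units; beyond the scatter)). Going by the values given here, no measured compound carries ethoxymethyl, so this guide is only rough. In this assay, removing cyclopentyl is expected to recover part or all of that drop, giving a modest rise (a 2.5-fold higher number from compound 2 to compound 3 (0.40 log units; beyond the scatter)). For compound 3, the estimated value is 10 ug/mL (expected range 3 ug/mL to 30 ug/mL).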

Compound 3, solubility: 26 ug/mL
Compound 3: the middle estimate sits 2.6-fold (0.41 log units) below what was measured; the range from low to high includes it.
By their numbers in this assay, from the lowest: compound 2; then compound 1; then compound 3.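

Until now this position, on an aromatic carbon next to the ring nitrogen, had carried only rings of carbon, and in this assay the open chain ethoxymethyl brings a 6.5-fold higher number from compound 2 to compound 3 (0.81 log units; beyond the scatter). It also goes past the smaller ring, with a 2.2-fold higher number from compound 1 to compound 3 (0.34 log units; beyond the scatter), so the number at this position can rise above that of cyclopropyl and not only fall from it. No measurement at hand accounts for this rise.

With the ring leaving and the oxygen entering in one change, the compounds shown do not separate the two, and a plain butyl chain at this position would be the open comparison. Also open, going by these compounds, is how an amine or a longer ether chain would read here.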